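This account rests on a few compounds, and the source may have more. Where it says the series, first, only, none or still open, it means among the compounds named here.

Compound 1 `CCn1c(C(=O)NCCCN(C)C)ccc1C(CC)(CC)c1ccc(OCCC(O)(CC)CC)c(C)c1`: 2150 nM
Compound 2 `C=CCN(C)C(=O)c1ccc(C(CC)(CC)c2ccc(OCCC(O)(CC)CC)c(C)c2)n1CC`: 12800 nM

In a functional assay on PC-3 cells (Homo sapiens) for antiproliferative activity, read by MTT assay, with a stated time of 48 h (on this read-out lower numbers stand for stronger inhibition and higher numbers for weaker inhibition), compound 2 has the higher number of the two, so it is the weaker inhibitor. Compound 3 `C#CCCOC(=O)c1ccc(C(CC)(CC)c2ccc(OCCC(O)(CC)CC)c(C)c2)n1CC` keeps the shared core and differs from it at one place: (but-3-yn-1-yl)oxy in place of allyl(methyl)amino on a carbonyl carbon. That is, (but-3-yn-1-yl)oxy stands in place of allyl(methyl)amino on a carbonyl carbon. Among the compounds with values here, the only measured guide is a 6.0-fold higher number from compound 1 to compound 2 (0.77 log units; beyond the scatter), a modest step at the same carbon but involving a different group. It shows that this place can shift the number, yet it gives no firm direction here. The expected change is small, estimated as a 1.4-fold lower number from compound 2 to compound 3 (0.15 log units; within the scatter). Compound 3 is estimated at 9000 nM, with an expected range of 2500 nM to 30000 nM.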

Compound 3, half-maximal inhibitory concentration: > 50000 nM
Compound 3: a limit, no number; the forecaster's own chance of this, stated with the estimate: 15%; at least 5.5-fold (0.74 log units) between middle value and limit.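

In this assay, compound 3 gives a limit, not a number: the limit of > 50000 nM in this assay, at which 1 of the 3 values shown sits. Even so, the limit shows that this carbonyl carbon can move the number further than the first step did: (but-3-yn-1-yl)oxy in place of allyl(methyl)amino gives an at least 3.9-fold higher number from compound 2 to compound 3 (0.59 log units; beyond the scatter). In place of (3-(dimethylamino)propyl)amino, it gives an at least 23-fold higher number from compound 1 to compound 3 (1.36 log units; beyond the scatter), the largest step shown at this place. Going by these compounds, the change swaps the atom on the carbonyl and the chain together, so it remains open which of the two goes with the weaker inhibition. An amine carrying the but-3-yn-1-yl chain would separate them.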